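The compounds below may be only part of what the source reports. "The series", "measured", "known", "first", "only" and "open" are said of these compounds alone.

Measured compounds:
compound 1 `Cc1nn(-c2nc(-c3ccc(Cl)c(Cl)c3)c(SC(C)C)s2)c(C(=O)O)c1Cc1ccccc1[N+](=O)[O-]`, 20000 nM
compound 2 `Cc1nn(-c2nc(-c3ccc(Cl)c(Cl)c3)c(SC(C)C)s2)c(C(=O)O)c1-c1cnccn1`, 14000 nM
compound 3 `Cc1nn(-c2nc(-c3ccc(Cl)c(Cl)c3)c(SC(C)C)s2)c(C(=O)O)c1-c1cnn(C)c1`, 6800 nM

In a functional assay on BJAB cells (Homo sapiens) for antiproliferative activity, with a stated time of 4 days (a lower number here means that less compound is needed, a higher number that more compound is needed for the effect), compound 3 gives the lowest of the three numbers; the step from compound 1 is a 2.9-fold lower number from compound 1 to compound 3 (0.47 log units; beyond the scatter) and from compound 2 it is a 2.1-fold lower number from compound 2 to compound 3 (0.31 log units; beyond the scatter), both beyond the scatter, so compound 3 is the most potent of the set. Compound 4 `Cc1nn(-c2nc(-c3ccc(Cl)c(Cl)c3)c(SC(C)C)s2)c(C(=O)O)c1-c1ccncc1` differs from compound 3 in one place: pyridin-4-yl in place of 1-methyl-1H-pyrazol-4-yl on an aromatic carbon. The measured step that bears on this change is the one between a six-membered ring with two nitrogen atoms and the five-membered ring, a 2.1-fold lower number from compound 2 to compound 3 (0.31 log units; beyond the scatter), a modest gain; the step of a 1.4-fold lower number from compound 1 to compound 2 (0.15 log units; within the scatter) lies within the scatter. The entering pyridin-4-yl again brings a six-membered ring with one hetero atom, so a modest step in the other direction, back toward compound 2, is expected in this assay, a 1.6-fold higher number from compound 3 to compound 4 (0.21 log units; within the scatter). Compound 4 is therefore estimated at 11000 nM, with a range from 5000 nM to 25000 nM.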

Compound 4, half-maximal effective concentration: 5900 nM
Compound 4: middle estimate off by 1.9-fold (0.27 log units), on the high side, and the stated range covers the measured number.
By their numbers in this assay, from the lowest: compounds 4 and 3 (each within the scatter of the next); then compounds 2 and 1 (each within the scatter of the next).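

In this assay, the step from 1-methyl-1H-pyrazol-4-yl to pyridin-4-yl is a 1.2-fold lower number from compound 3 to compound 4 (0.06 log units; within the scatter), so at this position the five-membered and the six-membered ring cannot be told apart. Ring size alone therefore does not sort these compounds: compound 2 also carries a six-membered ring, yet pyrazin-2-yl and pyridin-4-yl differ by a 2.4-fold lower number from compound 2 to compound 4 (0.38 log units; beyond the scatter), and the step from 2-nitrobenzyl is a 3.4-fold lower number from compound 1 to compound 4 (0.53 log units; beyond the scatter), the widest in the set so far. No available information explains these differences.

As far as these compounds go, how a phenyl ring, or pyridin-3-yl with its ring nitrogen in another place, would compare at this position stays open. So does the effect of a small group without a ring, such as an amine or a short alkyl chain.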